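The source may report more compounds than this note shows. Statements on the series, on what has been measured and on what is new or still open speak of the compounds shown alone.

Measured compounds:
compound 1, `Nc1cc(N)c2nc(-c3ccccc3)c(Sc3ccc(F)cc3)nc2c1`, in a functional assay on DU-145 cells (Homo sapiens) for inhibition, read by sulforhodamine B assay, with a stated time of 48 h; on this read-out higher numbers stand for weaker inhibition of growth and lower numbers for stronger inhibition of growth: < 100000 nM
compound 2, `Nc1cc(N)c2nc(-c3ccccc3)c(Sc3ccc(Cl)c(Cl)c3)nc2c1`: 1510 nM
compound 3, `COc1ccc(CNc2nc3cc(N)cc(N)c3nc2-c2ccccc2)cc1OC`: 460 nM

The value of compound 1 in this assay is a limit of the assay and not a number. Among the values that are numbers, compound 3 has the lowest, and the nearest is compound 2, whose number lies higher by a gap beyond the scatter. Among the measured compounds shown here, the one step with two measured ends, a step that the limit leaves unreadable from compound 1 to compound 2, cannot be read for size on account of the limit of < 100000 nM in this assay, at which 1 of the 3 values shown sits, and it concerns the group on a sulfur rather than the position changed here.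

Compound 4, `Nc1cc(N)c2nc(-c3ccccc3)c(NCc3ccc(F)cc3)nc2c1`, differs from compound 3 by 4-fluorophenyl in place of 3,4-dimethoxyphenyl on a saturated chain carbon bound to a nitrogen on an aromatic ring. For the measured compounds named here, no measured step touches this position, so the size and direction of the step are open. The expectation is therefore a number near that of compound 3, with wide bounds; for compound 4 in this assay the estimate is 900 nM, between 250 nM and 4000 nM, meaning an expected step of a 2.0-fold higher number from compound 3 to compound 4 (0.29 log units; within the scatter).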

Compound 4, concentration for 50% growth inhibition: 1510 nM
Beside the measured number, compound 4's estimate is 1.7-fold (0.22 log units) below it, within the range that was stated.
By their numbers in this assay, from the lowest: compound 3; then compounds 2 and 4 (each within the scatter of the next).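

On the saturated chain carbon bound to a nitrogen on an aromatic ring, 4-fluorophenyl in place of 3,4-dimethoxyphenyl gives a 3.3-fold higher number from compound 3 to compound 4 (0.52 log units; beyond the scatter) in this assay, the first readable measure of a change at this position and one toward weaker inhibition of growth. On the aromatic carbon, (4-fluorobenzyl)amino in place of (3,4-dichlorophenyl)sulfanyl gives no change at the digits printed from compound 2 to compound 4 (within the scatter), so this pair does not separate the two groups. The step from compound 1 to compound 4 cannot be read, as the value of compound 1 is a limit and not a number: the limit of < 100000 nM in this assay, at which 1 of the 4 values shown sits.

As far as these compounds go, it remains open whether the step from 3,4-dimethoxyphenyl follows from losing the methoxy groups or from gaining the fluorine. Plain phenyl or 4-methoxyphenyl on the same chain carbon would address this, and a longer chain or a carboxylic acid at this position remains untested in the compounds shown here.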